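Bromo for phenyl at the distal aryl position

This account rests on a few compounds, and the source may have more. Where it says the series, first, only, none or still open, it means among the compounds named here.

Measured so far:
compound 1 `Cc1ccc(C2=NN(c3ccc(S(C)(=O)=O)cc3)C(=O)CC2)cc1` — 60.5%
compound 2 `COc1ccc(C2=NN(c3ccc(S(C)(=O)=O)cc3)C(=O)CC2)cc1` — 68.4%
compound 3 `CS(=O)(=O)c1ccc(N2N=C(c3ccc(-c4ccccc4)cc3)CCC2=O)cc1` — 21%

In a functional assay on the whole organism (strain Wistar) for inhibition, with Rattus norvegicus as the target, read by paw edema, with stated times of 30 min and 5 h, at a dose of 0.05 mmol/kg by the oral route (a lower number here means less inhibition, a higher number more inhibition at the dose given (going by the name of the read-out)), compound 1 gives 60.5% and compound 2 gives 68.4%; the step of a number 7.9 percentage points higher from compound 1 to compound 2 (within the scatter) is within the scatter, so these two stand together. Compound 3 gives 21%, the lowest of the three numbers: the steps of a number 39.5 percentage points lower from compound 1 to compound 3 (beyond the scatter) and a number 47.4 percentage points lower from compound 2 to compound 3 (beyond the scatter) are both large and beyond the scatter, so compound 3 stands clearly apart from the other two.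

Compound 4 `CS(=O)(=O)c1ccc(N2N=C(c3ccc(Br)cc3)CCC2=O)cc1` is not yet measured. It differs from compound 3 by bromo in place of phenyl on an aromatic carbon. The two steps that bear on this change are the ones leading into compound 3, where a small group on the aromatic carbon was replaced by phenyl and the number fell sharply in each case. Compound 4 reverses that kind of change, bromo being a single heavy atom where phenyl had six. A large upward step is therefore expected in this assay, of about the size of the drops seen before, so that compound 4 should land near compound 1 and compound 2 rather than near compound 3. For compound 4 the expected value is 55%, in the range 35% to 75%. The step of a number 34 percentage points higher from compound 3 to compound 4 (beyond the scatter) is the estimated one.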

Compound 4, a percentage reported as inhibition, in the whole organism at one dose (the size of the read-out at that dose, not a potency): 31.5%
Compound 4: the middle estimate sits 23.5 percentage points above what was measured; the whole stated range lies above it.
By their numbers in this assay, from the lowest: compound 3; then compound 4; then compounds 1 and 2 (each within the scatter of the next).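

In this assay bromo recovers only part of what phenyl loses at this position, with a number 10.5 percentage points higher from compound 3 to compound 4 (beyond the scatter) as the modest gain. Set against the small groups, bromo still falls short, with a number 29 percentage points lower from compound 1 to compound 4 (beyond the scatter) and a number 36.9 percentage points lower from compound 2 to compound 4 (beyond the scatter) on the same comparison. Taking away the ring of the phenyl is therefore not enough on its own to bring the number back to the level of methyl and methoxy, and nothing at hand accounts for the gap that remains.

Open, on these data alone, is where fluoro, chloro, an amine or a carboxylic acid on this aromatic carbon would fall relative to bromo and to methyl and methoxy. A read-out at one dose also leaves the potency of all four compounds unsettled.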